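Swapping the Benzyl Group on a Weak Nucleoside Series

A few compounds are considered here, and "the series" means these few. Any claim that something is new, unique, unknown or untested is made for them only; others in the source may bear on it.

Measured so far in a functional assay on K562 cells (Homo sapiens) for antiproliferative activity, with a stated time of 72 h; on this read-out lower numbers stand for stronger inhibition and higher numbers for weaker inhibition:
compound 1 `OC[C@H]1O[C@@H](n2cnc3c(NCc4ccc(Cl)cc4Cl)ncnc32)[C@H](O)[C@@H]1O` gives 106000 nM
compound 2 `COc1ccc(CNc2ncnc3c2ncn3C2OC(CO)[C@@H](O)[C@H]2O)c(O)c1` gives 80800 nM
compound 3 `COc1cc(O)cc(OC)c1CNc1ncnc2c1ncn2[C@@H]1O[C@H](CO)[C@@H](O)[C@H]1O` gives > 166000 nM, which is a limit of the assay and not a number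

All three share one core and differ only in the group carried on the saturated chain carbon bound to a nitrogen on the core. Compound 1 and compound 2 lie within the scatter of each other, so neither can be called the weaker or the stronger of the two. Compound 3 reached only (the limit of > 166000 nM in this assay, at which 1 of the 3 values shown sits).

Compound 4 `Cc1ccc(O)c(CNc2ncnc3c2ncn3[C@@H]2O[C@H](CO)[C@@H](O)[C@H]2O)c1` is not yet measured. It differs from compound 1 by 2-hydroxy-5-methylphenyl in place of 2,4-dichlorophenyl on a saturated chain carbon bound to a nitrogen on an aromatic ring. Within the data shown here, no measured pair shows a change of this kind, and the two numbers seen so far sit close together, so the step of a 1.1-fold lower number from compound 1 to compound 4 (0.03 log units; within the scatter) is expected to stay within the scatter. Compound 4 is estimated at 100000 nM, with a range from 40000 nM to 250000 nM.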

Compound 4, half-maximal inhibitory concentration: 16500 nM
Estimate against measurement, compound 4: 6.1-fold (0.78 log units) above; measured number below the stated range.
By their numbers in this assay, from the lowest: compound 4; then compounds 2 and 1 (each within the scatter of the next). At a limit, above all of these: compound 3.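

In this assay, among these compounds, replacing 2,4-dichlorophenyl with 2-hydroxy-5-methylphenyl gives a 6.4-fold lower number from compound 1 to compound 4 (0.81 log units; beyond the scatter) and is the first step that can be read, though a modest one. This shows that the group on the saturated chain carbon can change the number, even though both groups hold 8 heavy atoms. Nothing measured here explains the change. Still open, going by these compounds, is whether the hydroxy group, the methyl group or the loss of chlorine drives this step, and how an amine or a carboxylic acid on the same ring would read.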